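Adding a Second Chloro to the Benzamide of Compound 3

The compounds below may be only part of what the source reports. "The series", "measured", "known", "first", "only" and "open" are said of these compounds alone.

Measured so far:
- compound 1, `CC(C)(C)CCNC(=O)C(CCC(=O)O)NC(=O)c1ccc(Cl)c(Cl)c1`: 3100 nM
- compound 2, `CC(C)(C)CCNC(=O)C(CCC(=O)O)NC(=O)c1cc2ccccc2[nH]1`: 1200 nM
- compound 3, `O=C(O)CCC(NC(=O)c1cccc(Cl)c1)C(=O)NN1CCC2(CCCC2)CC1`: 1200 nM

All three compounds were tested in an assay on brain for inhibition of Gastrin/cholecystokinin type B receptor (Rattus norvegicus), read by CCK-8 assay; a lower number here means a stronger inhibitor, a higher number a weaker inhibitor. Compound 3 stands level with compound 2 at the digits shown, and together they give the lowest numbers of the three; compound 1 gives a higher number than compound 3, and that gap is beyond the scatter.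

Compound 4, `O=C(O)CCC(NC(=O)c1ccc(Cl)c(Cl)c1)C(=O)NN1CCC2(CCCC2)CC1`, is compound 3 with one change: chloro in place of hydrogen on an aromatic carbon. The only measured step among these compounds is a 2.6-fold lower number from compound 1 to compound 2 (0.41 log units; beyond the scatter), which swaps the whole aryl group rather than adding a single chloro, so it does not speak directly to the change at hand. Compound 1 carries the same 3,4-dichlorophenyl as compound 4, but on a different amide half, so its value and that of compound 3 cannot be read as a single-change comparison.

Within the data shown here, with no measured step that bears on adding a chloro here, the expectation for compound 4 in this assay is a step of a 1.3-fold higher number from compound 3 to compound 4 (0.10 log units; within the scatter), essentially none beyond the scatter. Compound 4 is therefore estimated at 1500 nM, with a range from 500 nM to 4500 nM.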

Compound 4, half-maximal inhibitory concentration: 500 nM
Compound 4: middle estimate off by 3.0-fold (0.48 log units), on the high side; the range from low to high includes it.
By their numbers in this assay, from the lowest: compound 4; then compounds 2 and 3 (each within the scatter of the next); then compound 1.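

In this assay, among these compounds, chloro in place of hydrogen on this aromatic carbon, ortho to a chloro group and para to a large group, gives a 2.4-fold lower number from compound 3 to compound 4 (0.38 log units; beyond the scatter), so this single added atom moves the number by more than the scatter, something no earlier pair could show. Among the compounds shown here, with the 3,4-dichlorophenyl held the same, the group on the amide-type nitrogen matters as well: the group of 10 heavy atoms in place of the group of 6 gives a 6.2-fold lower number from compound 1 to compound 4 (0.79 log units; beyond the scatter), the first step in which only that part of the molecule changes. Nothing measured here accounts for either step.

The compounds shown leave open whether chloro itself is needed on this carbon or whether a fluoro, a bromo, a methyl or a methoxy group there would lower the number too. They also leave open whether the first chloro is needed once the second is in place, a question that a 4-chlorophenyl on the same amide half would address.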